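Swapping the Aryl Group on the Ring Nitrogen

A few compounds are considered here, and "the series" means these few. Any claim that something is new, unique, unknown or untested is made for them only; others in the source may bear on it.

In a functional assay, tested at 200 ug/mL (a lower number here means a stronger effect, a higher number a weaker effect of the compound at the concentration tested), the measured compounds gave:

Compound 1, `COC(=O)C1=C(C)N(c2ccc(OC)cc2)C=C(C)C1c1ccccc1`: -22.6%
Compound 2, `COC(=O)C1=C(C)N(c2ccccc2)C=C(C)C1c1ccccc1`: -33.1%
Compound 3, `COC(=O)C1=C(C)N(c2cccc(Cl)c2)C=C(C)C1c1ccccc1`: -23%

Compound 3 has the second highest of the three numbers. It lies nearest to compound 1, a gap within the usual scatter, and furthest from compound 2, a gap beyond the scatter. Within the data shown here, two steps bear on the change considered here: a number 10.1 percentage points higher from compound 2 to compound 3 (beyond the scatter), a modest rise when chloro replaces hydrogen on an aromatic carbon, and a number 10.5 percentage points lower from compound 1 to compound 2 (beyond the scatter), a modest fall when hydrogen replaces methoxy; the step of a number 0.4 percentage points lower from compound 1 to compound 3 (within the scatter) stays within the scatter. So a bare phenyl on the ring nitrogen gave the lowest number, and each substituted phenyl gave a modestly higher one, with the two substituted rings close to each other.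

Compound 4, `COC(=O)C1=C(C)N(c2cccc(C)c2C)C=C(C)C1c1ccccc1`, differs from compound 3 by 2,3-dimethylphenyl in place of 3-chlorophenyl on an amine nitrogen in a ring. Since this exchanges one substituted ring for another, any step in this assay is expected to be small, with a slight lean upward. Compound 4 is therefore expected to give -20%, within a range from -32% to -8%. That estimate corresponds to an expected step of a number 3 percentage points higher from compound 3 to compound 4 (within the scatter), within the scatter.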

Compound 4, a percentage reported as activity, at one concentration (the size of the read-out at that concentration, not a potency): -29.3%
Beside the measured number, compound 4's estimate is 9.3 percentage points above it; measured number inside the range.
By their numbers in this assay, from the lowest: compounds 2, 4, 3 and 1 (each within the scatter of the next, the first and the last beyond it).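

In this assay the 2,3-dimethylphenyl group on the amine nitrogen stays close to every earlier aryl group, with a number 6.3 percentage points lower from compound 3 to compound 4 (within the scatter) and a number 3.8 percentage points higher from compound 2 to compound 4 (within the scatter) and a number 6.7 percentage points lower from compound 1 to compound 4 (within the scatter) as its three steps. Compound 4 therefore goes against the earlier reading that a substituted phenyl stands modestly apart from the bare phenyl of compound 2, since this ring carries two methyl groups and still lies within the scatter of compound 2. Nothing available gives a reason for these numbers.

As far as these compounds go, whether an amine or a carboxylic acid on this aryl ring would move the number beyond the scatter remains open. Also open, from the compounds shown here alone, is what a longer chain would do in place of the aryl ring on the amine nitrogen.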